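The source may hold more compounds than are shown below. What is called first, only, known or untested is meant among the compounds shown, and "the series" means these compounds.

Among the compounds with values here, in a toxicity assay on MRC5 cells (Homo sapiens) for inhibition, read by MTT assay, with a stated time of 72 h (on this read-out higher numbers stand for weaker inhibition and lower numbers for stronger inhibition), compound 3 (`CCCCCCCC(=O)OCCc1ccc(O)cc1`) gives 133000 nM, the only true number so far. Compound 1 (`CCCCCCCCCCCCCC(=O)OCCc1ccc(O)c(O)c1`) reads > 50000 nM, which is a limit of the assay and not a number. Compound 2 (`CCCCCCCCCCCCCCCC(=O)OCCc1ccc(O)c(O)c1`) reads > 50000 nM, again a limit. The one measured step among these is a step that the two limits leave unreadable from compound 1 to compound 2, so it offers no size to lean on.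

Compound 4 (`CCCCCCCC(=O)OCCc1ccc(O)c(O)c1`) is compound 3 with one change: hydroxy in place of hydrogen on an aromatic carbon. In words, a hydroxy takes the place of a hydrogen on an aromatic carbon, ortho to a hydroxy group. Within the data shown here, no measured step shows this change on its own. The closest hint comes from compounds 1 and 2, which also carry this extra hydroxy but have longer chains, and both stop at the limit of > 50000 nM in this assay, at which 2 of the 3 values shown sit. That hint shows no readable size, so only a modest shift toward stronger inhibition in this assay is expected, held loosely, and a reading that is again only a limit remains quite possible. The expected change is a 2.2-fold lower number from compound 3 to compound 4 (0.35 log units; beyond the scatter). Compound 4 is estimated at 60000 nM, with an expected range of 20000 nM to 150000 nM.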

Compound 4, half-maximal inhibitory concentration: 104000 nM
Compound 4: middle estimate off by 1.7-fold (0.24 log units), on the low side; low and high end bracket the measured number.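

In this assay, within the data shown here, putting a hydroxy in place of hydrogen on the aromatic carbon, ortho to a hydroxy group, now has a readable size for the first time: a 1.3-fold lower number from compound 3 to compound 4 (0.11 log units; within the scatter). That step lies within the scatter, so compound 3 and compound 4 cannot be told apart in this assay, and at this chain length the extra hydroxy makes no readable difference. Compound 1 and compound 2 each stop at a limit of the assay and not at a number, so the steps from them to compound 4 cannot be read: the limit of > 50000 nM in this assay, at which 2 of the 4 values shown sit.

Among these compounds, this leaves a single readable pair, at one chain length, as the only evidence for this change, and whether the hydroxy would also make no readable difference on a longer or a shorter chain stays open. From the compounds shown here alone, it is also open how a methoxy group or a fluorine at the same place on the ring would read in this assay, or whether an amide in place of the ester link would move the number at all.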